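The source may hold more compounds than are shown below. What is called first, only, known or untested is meant among the compounds shown, and "the series" means these compounds.

Working notes on the series.

Of the compounds shown here, two have been tested in an assay on tissue (RPTEC cells) for inhibition of solute carrier family 22 member 12 (Homo sapiens), read by scintillation counting, with stated times of 15 min and 2 h; on this read-out higher numbers stand for weaker inhibition and lower numbers for stronger inhibition. Compound 1 `CSc1cc(C(=O)N2CCc3ccccc32)cc(C#N)c1O` reaches only the limit of the assay and gives no number: in this assay compound 1 gives > 100000 nM. Compound 2 `N#Cc1cc(C(=O)N2CS(=O)(=O)c3ccccc32)cc(Cl)c1O` likewise stops at the limit and gives no number: in this assay compound 2 gives > 100000 nM. Where compound 2 stands is therefore set by the limit of > 100000 nM in this assay, at which 2 of the 2 values shown sit, and nothing places either compound on a scale against the other; both sit at the same limit, so no order between them can be read.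

Compound 3 `CCc1cc(C(=O)N2CS(=O)(=O)c3ccccc32)cc(C#N)c1O` is not yet measured. It differs from compound 2 by ethyl in place of chloro on an aromatic carbon. Within the data shown here, no step between two measured compounds exists in this set, so no measured change gives a scale for this exchange. With compound 2 already at the limit, the expected step from compound 2 to compound 3 is a number no higher from compound 2 to compound 3 (the limit leaves the size open), which is to say none beyond the scatter. Compound 3 is estimated at 100000 nM, between 30000 nM and 300000 nM, most probably reported as a limit again.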

Compound 3, half-maximal inhibitory concentration: > 100000 nM
Compound 3: no number, only a limit; the forecaster's own chance of this, stated with the estimate: 85%; the middle value sits exactly at the limit.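

Compound 2 and compound 3 both stop at a limit, so no step can be read for ethyl in place of chloro on an aromatic carbon. What stays open is how the three compounds rank against one another and whether any change to the shared core gives a number in this assay: the limit of > 100000 nM in this assay, at which 3 of the 3 values shown sit.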